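The compounds below may be only part of what the source reports. "The series", "measured", "known", "first", "only" and "open" are said of these compounds alone.

Among the compounds with values here, in an ADME assay on HepG2 cells (Homo sapiens) for cytotoxicity (a lower number here means that less compound is tolerated, a higher number that more compound is tolerated), compound 2 `CSc1cccc(N(C(=O)c2cc3ccc(C(F)(F)F)cc3[nH]2)[C@@H](C)C(=O)NC2CCCC2)c1` gives 7100 nM, the only actual number so far. Compound 1 `CSc1cccc(N2C(=O)c3ccc(-c4ccco4)n3CC2(C)C(=O)NC2CCCC2)c1` has a different core and reaches only the assay limit of > 50000 nM. That entry is a limit and not a number, so it gives no exact gap to compound 2.

The next compound is compound 3 `CSc1cccc(N(C(=O)c2cc3ccc(C(F)(F)F)cc3[nH]2)[C@H](C)C(=O)NC2CCCC2)c1`. The change is the two compounds have the same atoms and bonds and differ only in configuration as drawn: 1 of 1 stereo elements differ; a stereocentre at a saturated chain carbon is drawn S in compound 2 and R in compound 3. Put simply, the stereocentre at a saturated chain carbon is drawn S in compound 2 and R in compound 3, and nothing else differs.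

Within the data shown here, no measured pair differs only in configuration, so the size of this step has no direct precedent. With compound 2 at 7100 nM as the sole anchor, no shift beyond the scatter is expected in this assay, and no firm direction is assigned. The expected step of a 1.1-fold higher number from compound 2 to compound 3 (0.05 log units; within the scatter) is therefore small. Compound 3 is expected at 8000 nM. The estimated range for compound 3 runs from 3500 nM to 20000 nM.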

Compound 3, half-maximal cytotoxic concentration: 15000 nM
For compound 3 the middle estimate is 1.9-fold (0.27 log units) below the measured one; measured number inside the range.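

In this assay, the stereocentre at a saturated chain carbon now has its first direct reading, and inverting it from S to R gives a 2.1-fold higher number from compound 2 to compound 3 (0.32 log units; beyond the scatter). The shift can be assigned to configuration alone because no other structural difference separates the pair: the fact that compounds 2 and 3 differ only in the configuration as drawn. Within this one pair, the R drawing tolerates more compound than the S drawing, so the two drawings of this stereocentre cannot be treated as interchangeable in this series, although the step is only modest and a single pair establishes no general rule.

Compound 1 gives > 50000 nM, which is a limit and not a number, so it cannot show how the core of compound 1 ranks against either drawing of the shared core. Also open is whether the same preference for the R drawing would persist with a longer chain or an amine on the stereocentre, since every compound shown from this pair carries the same small chain there and only one inversion can be read.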